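The source may hold more compounds than are shown below. What is called first, only, known or untested is meant among the compounds shown, and "the series" means these compounds.

Three compounds built on one shared core have been examined in an ADME assay on WI-38 cells (Homo sapiens) for cytotoxicity, read by MTT assay, with a stated time of 72 h; on this read-out lower numbers stand for stronger inhibition and higher numbers for weaker inhibition. Compound 1 `C#Cc1ccc(NC(=O)CCc2cccc3c2B(O)OC3)cc1` carries an ethynyl group, compound 2 `COc1ccc(NC(=O)CCc2cccc3c2B(O)OC3)cc1` carries a methoxy group at the same place, and compound 3 `COc1ccccc1NC(=O)CCc1cccc2c1B(O)OC2` is made of the same atoms as compound 2 joined differently; the difference between those two cores is not broken down here. In this assay compound 1 gives only a limit of the assay, > 100000 nM. Compound 2 likewise gives only a limit, > 100000 nM. For the measured compounds named here, compound 3 gives 1600 nM, the one plain number among the three.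

The change from compound 2 to compound 1 is ethynyl in place of methoxy on an aromatic carbon. The step it made is a step that the two limits leave unreadable from compound 2 to compound 1. Both of those values sit at the limit of > 100000 nM in this assay, at which 2 of the 3 values shown sit, so the size of that step cannot be read.

Compound 4 `C#Cc1ccccc1NC(=O)CCc1cccc2c1B(O)OC2` has not yet been measured. It differs from compound 3 by ethynyl in place of methoxy on an aromatic carbon. Going by the values given here, this is the same kind of change as the one from compound 2 to compound 1, but not the same: there the group stands para to a large group, here it stands ortho to a large group. The earlier example of this kind of change is unreadable, so no measured guide exists for its size. The step from compound 3 to compound 4 is therefore expected to be modest, a 1.6-fold higher number from compound 3 to compound 4 (0.19 log units; within the scatter), resting only on compound 3 and its value of 1600 nM. Compound 4 is expected to give about 2500 nM, between 500 nM and 30000 nM.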

Compound 4, half-maximal inhibitory concentration: 18000 nM
Beside the measured number, compound 4's estimate is 7.2-fold (0.86 log units) below it, and the stated range covers the measured number.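

In this assay, ethynyl in place of methoxy on an aromatic carbon, ortho to a large group, gave an 11-fold higher number from compound 3 to compound 4 (1.05 log units; beyond the scatter), so on the core of compound 3 this change clearly goes with weaker inhibition. The same change on the core of compound 2 cannot be sized, because compound 2 and compound 1 both give only a limit of the assay: the limit of > 100000 nM in this assay, at which 2 of the 4 values shown sit. The readable step therefore comes from one core alone, so it neither confirms nor rules out a similar step on the other core, and a single pair sets no rule for the series.

Methoxy and ethynyl have the same count of heavy atoms, while methoxy has one hydrogen-bond acceptor and ethynyl has none, but this one pair cannot tell whether that difference explains the step. As far as these compounds go, it also remains open how an amine, a carboxylic acid or a longer chain at the same place on the core of compound 3 would compare, and whether any of these would move the number in the same direction as ethynyl.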